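Removing the Chloro Group: What to Expect for Compound 4

The compounds below may be only part of what the source reports. "The series", "measured", "known", "first", "only" and "open" are said of these compounds alone.

Compound 1 `Cc1cc(C)n2nc(SCc3cc(=O)c4cc(Cl)ccc4o3)nc2n1` and compound 3 `Nc1nnc(SCc2cc(=O)c3cc(Cl)ccc3o2)s1` both carry a chloro group on a fused aromatic ring but differ elsewhere; the difference between the two cores is not broken down here. In a functional assay on MDA-MB-435S cells (Homo sapiens) for cytotoxicity, read by MTT assay, with a stated time of 72 h (a lower number here means a stronger inhibitor, a higher number a weaker inhibitor), compound 1 gives > 25000 nM, which is a limit of the assay rather than a number. Compound 3 likewise gives only a limit in this assay, > 25000 nM. Compound 2 `Nc1nnc(SCc2cc(=O)c3ccccc3o2)s1` arises from compound 3 through the change (hydrogen in place of chloro on an aromatic carbon). In this assay compound 2 also gives a limit, > 25000 nM. The step that the two limits leave unreadable from compound 3 to compound 2 cannot be read because both values sit at the limit of > 25000 nM in this assay, at which 3 of the 3 values shown sit. Compound 4 `Cc1cc(C)n2nc(SCc3cc(=O)c4ccccc4o3)nc2n1` stands to compound 1 as compound 2 stands to compound 3, through the change (hydrogen in place of chloro on an aromatic carbon), the same change at the same place. Compound 4 is therefore expected to give roughly 40000 nM in this assay, within an estimated range from 15000 nM to 150000 nM. This expected step that the limit leaves unreadable from compound 1 to compound 4 rests on a step that the two limits leave unreadable from compound 3 to compound 2 being unreadable and on every measured value sitting at the limit of > 25000 nM in this assay, at which 3 of the 3 values shown sit.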

Compound 4, half-maximal inhibitory concentration: > 25000 nM
Compound 4 gave a limit, no number; the forecaster's own chance of this, stated with the estimate: 85%; the middle value lies beyond the limit too.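

No new step can be read from compound 1 to compound 4, because in this assay both compounds give only a limit of the assay and not a number: the limit of > 25000 nM in this assay, at which 4 of the 4 values shown sit.

The compounds shown leave open how strongly any of the four acts in this assay, and whether hydrogen in place of chloro on an aromatic carbon changes that at all.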